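The source may hold more compounds than are shown below. What is called first, only, known or untested is meant among the compounds shown, and "the series" means these compounds.

Measured so far: compound 1 `O=c1c(C2N=C(c3ccccc3)SS2)coc2ccc(Cl)cc12` gives 66500 nM in a functional assay on OVCAR-3 cells (Homo sapiens) for inhibition, read by sulforhodamine B assay, with a stated time of 48 h; a lower number here means a stronger inhibitor, a higher number a weaker inhibitor; compound 3 `O=c1c(C2N=C(c3ccccc3)SS2)coc2cc(Cl)ccc12` gives 10500 nM. Compound 2 `O=c1c(C2N=C(c3ccccc3)SS2)coc2ccc(F)cc12` reaches only the limit of > 100000 nM, which is a limit of the assay and not a number.

Compound 3 thus holds the lowest of the two numbers, its gap to compound 1 lying beyond the scatter. Compound 4 `O=c1c(C2N=C(c3ccccc3)SS2)coc2ccccc12` differs from it by hydrogen in place of chloro on an aromatic carbon. Within the data shown here, the one measured step that bears on a change at a halogen is an at least 1.5-fold higher number from compound 1 to compound 2 (0.17 log units; that floor lies within the scatter), with a floor that is within the scatter, pointing towards a weaker inhibitor. Removing the chloro altogether is therefore expected to give compound 4 a higher number, estimated as a 2.9-fold higher number from compound 3 to compound 4 (0.46 log units; beyond the scatter). Compound 4 is expected at 30000 nM, within a range of 8000 nM to 100000 nM.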

Compound 4, half-maximal inhibitory concentration: > 100000 nM
Compound 4: no number, only a limit; the forecaster's own chance of this, stated with the estimate: 20%; middle value at least 3.3-fold (0.52 log units) away from the limit.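

Compound 4 stands at a limit of the assay, not a number, yet hydrogen in place of chloro still gives an at least 9.5-fold higher number from compound 3 to compound 4 (0.97 log units; beyond the scatter) in this assay, so the chloro at this place matters for the number of compound 3. Starting from the chloro of compound 1, the same change gives only an at least 1.5-fold higher number from compound 1 to compound 4 (0.17 log units; that floor lies within the scatter), which does not separate the two. The step between compound 2 and compound 4 cannot be read, and the limit bounds what these compounds can show: the limit of > 100000 nM in this assay, at which 2 of the 4 values shown sit.

Going by these compounds, whether a bromo, a methoxy or an amine at the place of the chloro in compound 3 would keep, lower or raise its number stays open.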